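Moving the Amine Around a Small Ring

The source may hold more compounds than are shown below. What is called first, only, known or untested is meant among the compounds shown, and "the series" means these compounds.

Compound 3 `CCCCCCCCCCc1ccc(-c2noc([C@H]3CCCN3)n2)cc1` stands lowest of the three measured compounds in an assay on HeLa cells for inhibition of sphingosine-1-phosphate transporter SPNS2 (Mus musculus), read by LC-MS, tested at 2 uM (a higher number here means more inhibition at the concentration tested (going by the name of the read-out), a lower number less inhibition), giving 12%. Compound 1 `CCCCCCCCCCc1ccc(-c2noc(C3CNC3)n2)cc1` gives 65% in this assay, and compound 2 `CCCCCCCCCCc1ccc(-c2noc(CCCNC)n2)cc1` gives 45%. The step of a number 53 percentage points lower from compound 1 to compound 3 (beyond the scatter) and the step of a number 33 percentage points lower from compound 2 to compound 3 (beyond the scatter) both show that pyrrolidin-2-yl on the shared core sits well below the other two groups.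

Compound 4 `CCCCCCCCCCc1ccc(-c2noc([C@@H]3CC[C@H](N)C3)n2)cc1` differs from compound 3 by 3-aminocyclopentyl in place of pyrrolidin-2-yl on an aromatic carbon. Among the compounds with values here, no measured step covers exactly this exchange, so the bearing is indirect: compound 1 carries azetidin-3-yl and compound 2 carries 3-(methylamino)propyl, and both of these give clearly higher inhibition than pyrrolidin-2-yl in compound 3. Because compound 1 reaches 65% and compound 2 reaches 45%, a rise from compound 3 is expected, but its size is uncertain, as 3-aminocyclopentyl has not been tested here.

The expected step is a number 28 percentage points higher from compound 3 to compound 4 (beyond the scatter). For compound 4 the estimate in this assay is 40%, with a range from 15% to 65%.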

Compound 4, a percentage reported as inhibition, at one concentration (the size of the read-out at that concentration, not a potency): 38%
The estimate for compound 4 lay 2 percentage points above the measured number; measured number inside the range.
By their numbers in this assay, from the lowest: compound 3; then compounds 4 and 2 (each within the scatter of the next); then compound 1.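

In this assay, moving the nitrogen out of the ring gives 3-aminocyclopentyl, and the step is a number 26 percentage points higher from compound 3 to compound 4 (beyond the scatter), so a five-membered ring at this place on the shared core does not by itself hold the number as low as pyrrolidin-2-yl does. The ring with its outer amine cannot be told apart from the open chain 3-(methylamino)propyl, with a step of a number 7 percentage points lower from compound 2 to compound 4 (within the scatter), while azetidin-3-yl stays ahead, with a step of a number 27 percentage points lower from compound 1 to compound 4 (beyond the scatter). Nothing measured here explains these differences.

The compounds shown leave open whether ring size or the place of the nitrogen matters more, since these groups differ in both at once. A piperidin-4-yl group, a six-membered ring with its nitrogen inside, or the other stereoisomers of 3-aminocyclopentyl would help to separate these factors.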